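The source may report more compounds than this note shows. Statements on the series, on what has been measured and on what is new or still open speak of the compounds shown alone.

Measured so far in an assay on HEK293 cells for displacement of a labelled ligand from adenosine receptor A2b (Homo sapiens), read by scintillation counting, with a stated time of 30 min, tested at 10 uM; on this read-out lower numbers stand for less inhibition and higher numbers for more inhibition at the one concentration tested (going by the name of the read-out): compound 1 `N=c1oc2ccc(Br)cc2cc1C(=O)NC1CCCCC1` gives 10%; compound 2 `COc1cccc2cc(C(=O)NCC(O)CO)c(=O)oc12` gives 25%; compound 3 `COc1cccc2c1OC(C)(O)C(C(C)=O)=C2` gives 24%.

Compound 2 stands highest of the three numbers in this assay, but its margin over compound 3 lies within the scatter, so only its gap to compound 1 counts as a real difference.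

Compound 4 `COc1cccc2cc(C(=O)NCCO)c(=O)oc12` has not yet been measured. Its change from compound 2 reads: hydrogen in place of hydroxymethyl on a saturated chain carbon bound to an oxygen on a saturated carbon and a saturated chain carbon. Among the measured compounds shown here, no step between measured compounds illuminates this change, so the expectation rests on compound 2 alone. A small step is expected for this assay, none beyond the scatter in either direction, so that the move a number 3 percentage points lower from compound 2 to compound 4 (within the scatter) is estimated as slight. For compound 4 the estimate in this assay is 22%, in a range from 8% to 38%.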

Compound 4, a percentage reported as inhibition, at one concentration (the size of the read-out at that concentration, not a potency): 7%
Estimate against measurement, compound 4: 15 percentage points above; measured number outside the range, below it.
By their numbers in this assay, from the lowest: compounds 4 and 1 (each within the scatter of the next); then compounds 3 and 2 (each within the scatter of the next).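

In this assay, among the compounds shown here, the change from 2,3-dihydroxypropyl to 2-hydroxyethyl comes with a number 18 percentage points lower from compound 2 to compound 4 (beyond the scatter), the only step between compounds that differ in one place. The hydroxymethyl on this saturated chain carbon is therefore not a silent part of the structure. Nothing at hand bears on the reason for this step. A single step cannot separate the loss of the hydroxyl from the shortening of the chain. As far as these compounds go, a longer chain ending in a hydroxyl, an amine or a carboxylic acid at this place remains open.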